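Pendant phenyl substituent series: from compound 2 to compound 3

The source may report more compounds than this note shows. Statements on the series, on what has been measured and on what is new or still open speak of the compounds shown alone.

compound 1 `COc1ccc2cc(C(C)c3nnc4n3N=C(c3ccc([N+](=O)[O-])cc3)CS4)ccc2c1` — 14700 nM
compound 2 `COc1ccc2cc(C(C)c3nnc4n3N=C(c3ccc(F)cc3)CS4)ccc2c1` — 7000 nM

In a functional assay on Huh-7 cells (Homo sapiens) for inhibition, read by sulforhodamine B assay, with a stated time of 72 h (a lower number here means a stronger inhibitor, a higher number a weaker inhibitor), compound 1 gives 14700 nM and compound 2 gives 7000 nM. Going by the values given here, compound 2 therefore stands at the lowest of the two numbers, and the one measured step, a 2.1-fold lower number from compound 1 to compound 2 (0.32 log units; beyond the scatter), is modest. Compound 3 `COc1ccc2cc(C(C)c3nnc4n3N=C(c3ccc(C(F)(F)F)cc3)CS4)ccc2c1` is not yet measured. The change is trifluoromethyl in place of fluoro on an aromatic carbon, on an aromatic carbon of a six-membered aromatic ring of carbon only, para to a large group. Among the compounds with values here, no measured step covers this exact exchange; the only comparison at the same place, a 2.1-fold lower number from compound 1 to compound 2 (0.32 log units; beyond the scatter), shows that swapping one group for another on this ring moved the number only a little. The expected step from compound 2 is therefore small, a 1.1-fold lower number from compound 2 to compound 3 (0.03 log units; within the scatter), with no firm direction beyond the scatter. Compound 3 is estimated at 6500 nM in this assay, with a range from 2500 nM to 17000 nM.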

Compound 3, half-maximal inhibitory concentration: 14800 nM
Beside the measured number, compound 3's estimate is 2.3-fold (0.36 log units) below it, within the range that was stated.
By their numbers in this assay, from the lowest: compound 2; then compounds 1 and 3 (each within the scatter of the next).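

In this assay, the change from 4-fluorophenyl to 4-(trifluoromethyl)phenyl gives a 2.1-fold higher number from compound 2 to compound 3 (0.33 log units; beyond the scatter), so the earlier gain on leaving nitro is not a general feature of replacing that group at this place. Trifluoromethyl in place of nitro gives a 1.0-fold higher number from compound 1 to compound 3 (0.00 log units; within the scatter), which leaves these two groups indistinguishable here, while fluoro alone stands apart, with steps beyond the scatter to both of the others. No supporting data bear on why the fluoro compound separates from the other two.

The compounds shown leave open whether an amine or a carboxylic acid at this place would give a number on either side of that of compound 2. They also leave open whether fluoro keeps its standing when the rest of the shared core is changed.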